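Sulfamoyl to acetamido at the aromatic carbon

A few compounds are considered here, and "the series" means these few. Any claim that something is new, unique, unknown or untested is made for them only; others in the source may bear on it.

Two compounds of the series have numbers in a functional assay for inhibition, with Homo sapiens as the target; on this read-out lower numbers stand for stronger inhibition and higher numbers for weaker inhibition. Compound 1 `CN(C)CCCOc1ccc(Nc2nccc(-c3cccnc3)n2)cc1` gives 600 nM. Among the measured compounds shown here, compound 2 `NS(=O)(=O)c1ccc(Nc2nccc(-c3cccnc3)n2)cc1` gives 200 nM, the lowest of the two values; the single measured step, a 3.0-fold lower number from compound 1 to compound 2 (0.48 log units; beyond the scatter), is the only comparison available and goes beyond the scatter. Compound 3 `CC(=O)Nc1ccc(Nc2nccc(-c3cccnc3)n2)cc1` is not yet measured. The change from compound 2 to compound 3 is acetamido in place of sulfamoyl on an aromatic carbon. For the measured compounds named here, no measured step bears directly on this exchange: the one step known so far, a 3.0-fold lower number from compound 1 to compound 2 (0.48 log units; beyond the scatter), concerns a 3-(dimethylamino)propoxy chain against sulfamoyl and says nothing about sulfamoyl against acetamido. The exchange keeps a hydrogen-bond donor at the same aromatic carbon while the acceptors become fewer, so there is no ground for a large shift in either direction. Compound 3 is therefore expected to stay close to compound 2, with an expected step of a 1.5-fold higher number from compound 2 to compound 3 (0.18 log units; within the scatter), inside or near the scatter. The estimate for compound 3 in this assay is 300 nM, with a range from 100 nM to 1000 nM.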

Compound 3, half-maximal inhibitory concentration: 3600 nM
Beside the measured number, compound 3's estimate is 12-fold (1.08 log units) below it; measured number outside the range, above it.
By their numbers in this assay, from the lowest: compound 2; then compound 1; then compound 3.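

In this assay this aromatic carbon, para to a large group, separates two groups that look alike by count: an 18-fold higher number from compound 2 to compound 3 (1.26 log units; beyond the scatter) even though sulfamoyl and acetamido each have 4 heavy atoms and 1 hydrogen-bond donor, and differ in count only as 2 hydrogen-bond acceptors against 1 hydrogen-bond acceptor. Acetamido also falls behind the 3-(dimethylamino)propoxy chain, with a 6.0-fold higher number from compound 1 to compound 3 (0.78 log units; beyond the scatter) in the same read-out, so the two groups of 4 heavy atoms end up on either side of compound 1 and heavy-atom count alone does not order these three compounds. Nothing at hand accounts for the gap between sulfamoyl and acetamido.

The compounds shown leave open which part of sulfamoyl carries the lower number, a question that a methylsulfonyl group, a carboxamide or a carboxylic acid at this carbon would help to narrow. They also leave open whether a step of this size between sulfamoyl and acetamido would hold with a change elsewhere on the shared core.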